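Triazole aryl swap on a free phenol core

A few compounds are considered here, and "the series" means these few. Any claim that something is new, unique, unknown or untested is made for them only; others in the source may bear on it.

Measured so far, in a functional assay on MCF7 cells (Homo sapiens) for cytotoxicity, read by MTT assay, with a stated time of 4 days; on this read-out lower numbers stand for stronger inhibition and higher numbers for weaker inhibition:
- compound 1 `C=C1C(=O)[C@]23C[C@@]1(O)CC[C@H]2c1ccc(OS(=O)(=O)c2ccc(C)cc2)c(C)c1[C@@H]3Cn1cc(-c2ccccn2)nn1` gives 320 nM
- compound 2 `C=C1C(=O)[C@]23C[C@@]1(O)CC[C@H]2c1ccc(O)c(C)c1[C@@H]3Cn1cc(-c2ccccc2)nn1` gives 1740 nM
- compound 3 `C=C1C(=O)[C@]23C[C@@]1(O)CC[C@H]2c1ccc(O)c(C)c1[C@@H]3Cn1cc(-c2ccccn2)nn1` gives 2240 nM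

Compound 3 stands at the highest of the three numbers shown, but its nearest neighbour is compound 2, and the two lie within the scatter of each other; only compound 1, which carries the (4-methylphenyl)sulfonyl group on the phenolic oxygen, sits clearly apart, as a 7.0-fold higher number from compound 1 to compound 3 (0.85 log units; beyond the scatter) shows. The step from compound 2 to compound 3, a 1.3-fold higher number from compound 2 to compound 3 (0.11 log units; within the scatter), exchanges the aryl group on the triazole and changes nothing beyond the scatter.

Compound 4 `C=C1C(=O)[C@]23C[C@@]1(O)CC[C@H]2c1ccc(O)c(C)c1[C@@H]3Cn1cc(-c2ccc(F)cc2)nn1` is formed from compound 3 by 4-fluorophenyl in place of pyridin-2-yl on an aromatic carbon. Among the measured compounds shown here, the only measured step that bears on this is the one between compound 2 and compound 3, which also swaps the aryl on the triazole while the free phenol is kept, and it was small. For the measured compounds named here, no measured pair informs on the fluorine itself. A step of no consequence beyond the scatter is therefore expected in this assay, with compound 4 landing near compound 2 and compound 3.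

Compound 4 is accordingly estimated at 1800 nM, with a range from 800 nM to 4000 nM, an expected step of a 1.2-fold lower number from compound 3 to compound 4 (0.09 log units; within the scatter).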

Compound 4, half-maximal inhibitory concentration: 1700 nM
Compound 4: middle estimate off by 1.1-fold (0.02 log units), on the high side; low and high end bracket the measured number.
By their numbers in this assay, from the lowest: compound 1; then compounds 4, 2 and 3 (each within the scatter of the next).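

With the free phenol kept, placing 4-fluorophenyl instead of pyridin-2-yl on the aromatic carbon of the five-membered aromatic ring with 3 nitrogen gives a 1.3-fold lower number from compound 3 to compound 4 (0.12 log units; within the scatter) in this assay, so a second aryl exchange at this position also stays within the scatter, this time with the ring nitrogen of pyridin-2-yl and its hydrogen-bond acceptor gone. The fluorine can now be read on its own: fluoro in place of hydrogen on an aromatic carbon gives a 1.0-fold lower number from compound 2 to compound 4 (0.01 log units; within the scatter), and phenyl, pyridin-2-yl and 4-fluorophenyl, carried by compound 2, compound 3 and compound 4, show no separation at this position. Nothing measured here offers a reason why these exchanges leave the number where it is.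

The compounds shown leave open whether an aryl group carrying an amine or a carboxylic acid, or a longer alkyl chain in place of the aryl ring, would also stay within the scatter. They also leave open whether phenyl or 4-fluorophenyl behaves as pyridin-2-yl does once the phenolic oxygen bears (4-methylphenyl)sulfonyl, as in compound 1.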